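This account rests on a few compounds, and the source may have more. Where it says the series, first, only, none or still open, it means among the compounds named here.

In a functional assay on CAKI-1 cells (Homo sapiens) for cytotoxicity, read by sulforhodamine B assay, with a stated time of 48 h (on this read-out lower numbers stand for stronger inhibition of growth and higher numbers for weaker inhibition of growth), compound 1 `CC1=C(C(=O)Nc2ccc(Cl)c(Cl)c2)C(c2cccc(O)c2)NC(=S)N1` gives 22400 nM. Compound 2 `CC1=C(C(=O)Nc2ccc(F)c(Cl)c2)C(c2cccc(Oc3ccccc3)c2)NC(=S)N1` gives 12600 nM in this assay; against compound 1 this lies within the usual scatter, so no order between the two compounds is established. Among the measured compounds shown here, compound 3 `CC1=C(C(=O)Nc2ccc(Cl)c(Cl)c2)C(c2cccc(Oc3ccccc3)c2)NC(=S)N1` differs from compound 2 by chloro in place of fluoro on an aromatic carbon; no measured pair shows this change. For the measured compounds named here, with no such step known, a shift beyond the scatter in this assay is not expected in either direction. Compound 3 is estimated at 11000 nM in this assay, with a range from 5000 nM to 25000 nM. The step expected from compound 2 to compound 3 is a 1.1-fold lower number from compound 2 to compound 3 (0.06 log units; within the scatter).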

Compound 3, concentration for 50% growth inhibition: 8510 nM
Estimate against measurement, compound 3: 1.3-fold (0.11 log units) above, within the range that was stated.
By their numbers in this assay, from the lowest: compounds 3, 2 and 1 (each within the scatter of the next, the first and the last beyond it).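

Chloro in place of fluoro on this aromatic carbon, ortho to a chloro group, gives a 1.5-fold lower number from compound 2 to compound 3 (0.17 log units; within the scatter) in this assay and so sets no order between the 3-chloro-4-fluorophenyl and 3,4-dichlorophenyl compounds. Phenyl in place of hydrogen on the oxygen on the aromatic ring gives a 2.6-fold lower number from compound 1 to compound 3 (0.42 log units; beyond the scatter) and is the first step in the series to pass the scatter, though only modestly. No available data bear on the reason for either step.

From the compounds shown here alone, whether bromo, methyl or hydrogen at the halogen position would separate from chloro and fluoro remains open. Also open, going by these compounds, is whether methyl or benzyl on that oxygen would match phenyl.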